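Trimethoxyphenyl Pyrazolyl Chalcones: One Methoxy Removed Twice

The source may report more compounds than this note shows. Statements on the series, on what has been measured and on what is new or still open speak of the compounds shown alone.

Four related compounds are considered here. Compound 1 `COc1cc(-c2cc(/C=C/C(=O)c3ccc(N)cc3)[nH]n2)cc(OC)c1OC` and compound 2 `COc1ccc(-c2cc(/C=C/C(=O)c3ccc(N)cc3)[nH]n2)cc1OC` share a core, as do compound 3 `COc1cc(C(=O)/C=C/c2cc(-c3cc(OC)c(OC)c(OC)c3)n[nH]2)cc(OC)c1OC` and compound 4 `COc1ccc(-c2cc(/C=C/C(=O)c3cc(OC)c(OC)c(OC)c3)[nH]n2)cc1OC`; how the core of compound 1 and the core of compound 3 differ is not broken down here. In a functional assay on NCI-H460 cells (Homo sapiens) for inhibition, read by sulforhodamine B assay, with a stated time of 48 h (on this read-out lower numbers stand for stronger inhibition of growth and higher numbers for weaker inhibition of growth), compound 1 gives 1800 nM, compound 2 gives 2030 nM, and compound 3 gives 1890 nM. The change from compound 1 to compound 2 is hydrogen in place of methoxy on an aromatic carbon, and in this assay it made the step of a 1.1-fold higher number from compound 1 to compound 2 (0.05 log units; within the scatter). Compound 4 differs from compound 3 by hydrogen in place of methoxy on an aromatic carbon, the same change at the same kind of place. Because compound 3 gives 1890 nM and the earlier step was a 1.1-fold higher number from compound 1 to compound 2 (0.05 log units; within the scatter), compound 4 is expected to sit close to compound 3, with an estimated step of a 1.1-fold higher number from compound 3 to compound 4 (0.02 log units; within the scatter) in this assay. On this basis compound 4 is estimated at 2000 nM in this assay, within a range from 1000 nM to 4200 nM. The measurement will tell whether the second removal of a methoxy group echoes the first.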

Compound 4, concentration for 50% growth inhibition: 1040 nM
For compound 4 the middle estimate is 1.9-fold (0.28 log units) above the measured one; measured number inside the range.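

In this assay, hydrogen in place of methoxy on the second core gave a 1.8-fold lower number from compound 3 to compound 4 (0.26 log units; within the scatter), so on this core too the change stays inside the usual spread of repeated measurements. Set beside the earlier step, the new one does not separate from it: the same change on two cores in this assay, a 1.1-fold higher number (0.05 log units; within the scatter) from compound 1 to compound 2 and a 1.8-fold lower number (0.26 log units; within the scatter) from compound 3 to compound 4, 2.0-fold (0.31 log units) apart, within the scatter of two such steps. Across these two pairs, then, the change carries from one core to the other without a step that can be told from the scatter, but this does not show that it is without effect in general, nor that the two cores would respond alike to any other change.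

The compounds shown hold only methoxy or hydrogen at this place, so it remains open whether a chlorine atom, a carboxylic acid or a longer chain there would give a step beyond the scatter. Also open, as far as these compounds go, is whether the same agreement between the two cores would hold on cells other than those of this assay.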